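Amide aryl swap in the anilinoquinazoline thioacetamide series

The source may hold more compounds than are shown below. What is called first, only, known or untested is meant among the compounds shown, and "the series" means these compounds.

Both measured compounds share the core of compound 1 `C=CC(=O)Nc1cccc(NC(=O)CSc2nc(Nc3ccccc3)c3ccccc3n2)c1` and differ only in the aryl group on the amide-type nitrogen. In a functional assay on NCI-H1975 cells (Homo sapiens) for inhibition, read by MTT assay, with a stated time of 72 h (on this read-out lower numbers stand for stronger inhibition and higher numbers for weaker inhibition), compound 1 gives 8120 nM. Going by the values given here, compound 2 `O=C(CSc1nc(Nc2ccccc2)c2ccccc2n1)Nc1ccc([N+](=O)[O-])cc1` carries a 4-nitrophenyl in that place and in this assay compound 2 gives 13000 nM, the highest of the two numbers so far; the step of a 1.6-fold higher number from compound 1 to compound 2 (0.20 log units; within the scatter) lies within the scatter, so neither compound can be ordered against the other.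

Compound 3 `O=C(CSc1nc(Nc2ccccc2)c2ccccc2n1)Nc1ccc(Cl)cc1Cl` is not yet measured. It differs from compound 2 by 2,4-dichlorophenyl in place of 4-nitrophenyl on an amide-type nitrogen. Among the compounds with values here, the only measured step that touches the same place is a 1.6-fold higher number from compound 1 to compound 2 (0.20 log units; within the scatter), and it stayed within the scatter. Nothing in the series therefore points to a large move in this assay for a further swap of the aryl group on the amide-type nitrogen, and the expected step of a 1.1-fold lower number from compound 2 to compound 3 (0.03 log units; within the scatter) is none beyond the scatter. Compound 3 is estimated to give 12000 nM in this assay, with a plausible range from 4000 nM to 36000 nM.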

Compound 3, half-maximal inhibitory concentration: 8410 nM
Beside the measured number, compound 3's estimate is 1.4-fold (0.15 log units) above it; measured number inside the range.
By their numbers in this assay, from the lowest: compounds 1, 3 and 2 (each within the scatter of the next).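

Working notes on the amide-type nitrogen: with 2,4-dichlorophenyl in place of 4-nitrophenyl, this assay gives a 1.5-fold lower number from compound 2 to compound 3 (0.19 log units; within the scatter) and so a third aryl group joins the series with no step beyond the scatter. The comparison with the acrylamide-bearing aryl group gives a 1.0-fold higher number from compound 1 to compound 3 (0.02 log units; within the scatter) and so 3-((vinylcarbonyl)amino)phenyl is not set apart from 2,4-dichlorophenyl here, and all three compounds remain unordered even though 4-nitrophenyl carries hydrogen-bond acceptors and 2,4-dichlorophenyl carries none. No measurement bearing on the reason for this flat picture is available.

Going by these compounds, whether any group on this nitrogen can produce a step beyond the scatter stays open, for example a 4-aminophenyl, a phenyl ring bearing a carboxylic acid, or a longer alkyl chain in place of the aryl ring. On these data alone, all three compounds also share the same core, so the effect of changes elsewhere, such as a methoxy group on the anilino phenyl, remains unknown in this assay.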